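Amino for Methoxy on a Thiophene-Bearing Fused Core

The source may hold more compounds than are shown below. What is called first, only, known or untested is meant among the compounds shown, and "the series" means these compounds.

Measured compounds:
Compound 1, `Cc1ncnc2[nH]cc(Sc3cccs3)c12`: 38100 nM
Compound 2, `COc1ncnc2[nH]cc(Sc3cccs3)c12`: 17200 nM
Compound 3, `c1coc(-c2ncnc3[nH]cc(Sc4cccs4)c23)c1`: 6750 nM

All three share one core and differ only in a single group on an aromatic carbon. In a functional assay on HCT-116 cells (Homo sapiens), read by MTT assay, with a stated time of 3 days (on this read-out lower numbers stand for stronger inhibition and higher numbers for weaker inhibition), compound 2 sits second highest of the three numbers, with compound 1 giving the higher number and compound 3 the lower one. The step of a 2.2-fold lower number from compound 1 to compound 2 (0.35 log units; beyond the scatter) and the step of a 2.5-fold lower number from compound 2 to compound 3 (0.41 log units; beyond the scatter) both go beyond the scatter and are modest in size.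

Compound 4, `Nc1ncnc2[nH]cc(Sc3cccs3)c12`, is not yet measured. Its difference from compound 2 is amino in place of methoxy on an aromatic carbon. Going by the values given here, two measured steps bear on this change. The step of a 2.2-fold lower number from compound 1 to compound 2 (0.35 log units; beyond the scatter) shows that swapping one small group for another on this carbon shifts the number modestly. The step of a 2.5-fold lower number from compound 2 to compound 3 (0.41 log units; beyond the scatter) shows a further modest gain when a ring enters in place of methoxy; the amino group brings no ring, so that gain is not a direct guide. A step no larger than these is therefore expected in this assay for the change in compound 4, and its direction is uncertain because a 2.2-fold lower number from compound 1 to compound 2 (0.35 log units; beyond the scatter) and a 2.5-fold lower number from compound 2 to compound 3 (0.41 log units; beyond the scatter) involve different kinds of groups. Compound 4 is estimated at 12000 nM, with a range from 4000 nM to 40000 nM, which means an expected step of a 1.4-fold lower number from compound 2 to compound 4 (0.16 log units; within the scatter).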

Compound 4, half-maximal inhibitory concentration: 22800 nM
Compound 4: the middle estimate sits 1.9-fold (0.28 log units) below what was measured; measured number inside the range.
By their numbers in this assay, from the lowest: compound 3; then compounds 2, 4 and 1 (each within the scatter of the next, the first and the last beyond it).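

In this assay, amino in place of methoxy gives a 1.3-fold higher number from compound 2 to compound 4 (0.12 log units; within the scatter) and so stays within the scatter, which means that on this aromatic carbon the read-out does not separate the two groups, even though amino carries a hydrogen-bond donor and methoxy carries none. Going by these compounds alone, compound 4 is likewise not separated from the methyl compound, with a 1.7-fold lower number from compound 1 to compound 4 (0.22 log units; within the scatter) also within the scatter, while a 3.4-fold higher number from compound 3 to compound 4 (0.53 log units; beyond the scatter) goes beyond it and makes furan-2-yl the only group here that stands clear of all three groups without a ring, although methyl and methoxy also differ from each other beyond the scatter. No measurement is available that would give a reason for these numbers or for the missing separation between amino and methoxy.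

The compounds shown leave open whether the advantage of compound 3 belongs to furan-2-yl itself or would carry over to another ring at this carbon, such as phenyl or thiophen-2-yl. They also leave open whether a larger amine, such as dimethylamino or morpholine, or a longer chain, such as propyl, would stay with the small groups or move towards compound 3.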